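A few compounds are considered here, and "the series" means these few. Any claim that something is new, unique, unknown or untested is made for them only; others in the source may bear on it.

Compound 1 `CCc1c(F)c(N)c2c(=O)cc(-c3ccc(N)c(F)c3)oc2c1F` is the point of reference. In a functional assay on MCF7 cells (Homo sapiens) for cytotoxicity, read by neutral red uptake, with a stated time of 3 days (on this read-out higher numbers stand for weaker inhibition and lower numbers for stronger inhibition), compound 1 gives 130 nM, and on the numbers shown it stands level with compound 3 `CCC(=O)OCc1c(F)c(N)c2c(=O)cc(-c3ccc(N)c(F)c3)oc2c1F`, which in this assay gives 130 nM; the step is no change at the digits printed from compound 1 to compound 3 (within the scatter). Compound 2 `CCCCCCc1c(F)c(N)c2c(=O)cc(-c3ccc(N)c(F)c3)oc2c1F` is reported only as a limit of the assay, > 10000 nM, not as a number (the limit of > 10000 nM in this assay, at which 1 of the 3 values shown sits). From there the step reads an at least 76-fold higher number from compound 1 to compound 2 (1.88 log units; beyond the scatter).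

Compound 4 `CCCCCC(=O)OCc1c(F)c(N)c2c(=O)cc(-c3ccc(N)c(F)c3)oc2c1F` has not yet been measured. It differs from compound 1 in one place: (pentylcarbonyl)oxy in place of methyl on a saturated chain carbon bound to an aromatic carbon. Within the data shown here, two measured steps bear on this. Replacing methyl with propanoyloxy in compound 3 left the number unchanged, whereas the longer chain in compound 2 pushed the number up to the limit of the assay. Compound 4 combines an ester with a longer chain, so a modest rise in the number is expected, a 1.9-fold higher number from compound 1 to compound 4 (0.28 log units; within the scatter). Compound 4 is therefore estimated at 250 nM, in the range 70 nM to 1500 nM.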

Compound 4, half-maximal inhibitory concentration: 160 nM
The estimate for compound 4 lay 1.6-fold (0.19 log units) above the measured number; the range from low to high includes it.
By their numbers in this assay, from the lowest: compounds 1, 3 and 4 (each within the scatter of the next). At a limit, above all of these: compound 2.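

In this assay, extending the ester chain changes nothing that can be told apart: a 1.2-fold higher number from compound 3 to compound 4 (0.09 log units; within the scatter), and the full exchange on the saturated chain carbon bound to an aromatic carbon reads a 1.2-fold higher number from compound 1 to compound 4 (0.09 log units; within the scatter). This position therefore tolerates a long chain when it carries the ester, so chain length alone does not set the result, as the contrast with the plain pentyl chain shows: an at least 62-fold lower number from compound 2 to compound 4 (1.79 log units; beyond the scatter). That step has a limit at one end, not a number, and compound 2 is the compound concerned: the limit of > 10000 nM in this assay, at which 1 of the 4 values shown sits.

The compounds shown leave open how long the ester chain can grow before the number moves, and whether an amide or an ether at this place would behave like the esters. They also leave open where between ethyl and the longest plain chain the number starts to rise, as a propyl or butyl chain could show.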